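Thiadiazole sulfanylacetamide series: allyl variant at the ring amine

The compounds below may be only part of what the source reports. "The series", "measured", "known", "first", "only" and "open" are said of these compounds alone.

Compound 1 `CC(C)CNc1nnc(SCC(=O)N(Cc2cccc([N+](=O)[O-])c2)c2ccc(F)cc2)s1` and compound 2 `COCCNc1nnc(SCC(=O)N(Cc2cccc([N+](=O)[O-])c2)c2ccc(F)cc2)s1` share the whole acetamide core and differ only in the chain on the ring-bound amine. In an assay on isolated protein for inhibition of Amine oxidase [flavin-containing] A (Homo sapiens), read by fluorescence and Amplex Red, with a stated time of 30 min, tested at 1 mM (a lower number here means a weaker effect, a higher number a stronger effect of the compound at the concentration tested), compound 1 gives 93.5% and compound 2 gives 94.1%. The step of a number 0.6 percentage points higher from compound 1 to compound 2 (within the scatter) shows that exchanging the chain end left the read-out essentially unchanged. Compound 2 thus holds the higher of the two numbers, with compound 1 within the scatter of it, so no order between them can be claimed.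

Compound 3 `C=CCNc1nnc(SCC(=O)N(Cc2cccc([N+](=O)[O-])c2)c2ccc(F)cc2)s1` continues this variation: vinyl in place of methoxymethyl on a saturated chain carbon bound to a nitrogen on an aromatic ring. Going by the values given here, the only step that bears on it is a number 0.6 percentage points higher from compound 1 to compound 2 (within the scatter), which was flat, so a move beyond the scatter is not expected in this assay. Compound 3 is expected to give 92%, with a range from 80% to 97%, an estimated step of a number 2.1 percentage points lower from compound 2 to compound 3 (within the scatter).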

Compound 3, a percentage reported as inhibition, at one concentration (the size of the read-out at that concentration, not a potency): 92%
The estimate for compound 3 equals the measured number at the digits printed, within the range that was stated.
By their numbers in this assay, from the lowest: compounds 3, 1 and 2 (each within the scatter of the next).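

Working from the methoxymethyl end, vinyl in place of methoxymethyl gives a number 2.1 percentage points lower from compound 2 to compound 3 (within the scatter) in this assay, and vinyl in place of isopropyl gives a number 1.5 percentage points lower from compound 1 to compound 3 (within the scatter). The earlier pair compared two saturated chain ends, whereas these steps show that a double bond outside aromatic rings is also accommodated at this place without a step beyond the scatter, and the same holds for the change to a chain end with no hydrogen-bond acceptor. All three chain ends therefore remain indistinguishable in this read-out, and no information is available to explain that flatness.

Going by these compounds, it remains open whether a carboxylic acid, a primary amine or a longer alkyl chain at this place would leave the read-out equally flat. Each percentage gives only the size of the read-out at the one concentration tested, and none of these three compounds can be assigned a stronger or weaker effect at that concentration.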